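This account rests on a few compounds, and the source may have more. Where it says the series, first, only, none or still open, it means among the compounds named here.

Compound 1: `C/C=C(\C)C(=O)Nc1ccn([C@H]2CC[C@H](O[C@H]3O[C@H](C)[C@@H](N(C)C)[C@H](O)[C@H]3O)[C@@H](C)O2)c(=O)n1` — 6450 nM
Compound 2: `CC(C)/C=C/C(=O)Nc1ccn([C@H]2CC[C@H](O[C@H]3O[C@H](C)[C@@H](N(C)C)[C@H](O)[C@H]3O)[C@@H](C)O2)c(=O)n1` — 780 nM

Among the two numbers measured in a functional assay on HCT-116 cells (Homo sapiens) for cytotoxicity, read by sulforhodamine B assay, with a stated time of 24 h (a lower number here means a stronger inhibitor, a higher number a weaker inhibitor), compound 2 stands at the lowest, its nearest neighbour being compound 1, a gap described by the single measured step, an 8.3-fold lower number from compound 1 to compound 2 (0.92 log units; beyond the scatter). That step altered the unsaturated chain on the carbonyl carbon as a whole, swapping one branched alkenyl group for another.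

Compound 3, `CCC(C)/C=C/C(=O)Nc1ccn([C@H]2CC[C@H](O[C@H]3O[C@H](C)[C@@H](N(C)C)[C@H](O)[C@H]3O)[C@@H](C)O2)c(=O)n1`, is the next member of the series and differs from compound 2 by methyl in place of hydrogen on a saturated chain carbon, two bonds along the chain from a double-bonded chain carbon. Going by the values given here, the one measured step bears on it only loosely: it concerns the same chain, but it exchanged the entire group rather than adding a single methyl at a saturated chain carbon, so it cannot be read as a direct guide. Nothing measured suggests a large move in either direction, and the most that can be said is that a step within or close to the scatter is expected.

Compound 3 is therefore expected to give about 650 nM in this assay, with a range of 250 nM to 1700 nM. The change from compound 2 is expected to amount to a 1.2-fold lower number from compound 2 to compound 3 (0.08 log units; within the scatter).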

Compound 3, half-maximal inhibitory concentration: 890 nM
Compound 3: middle estimate off by 1.4-fold (0.14 log units), on the low side, and the stated range covers the measured number.
By their numbers in this assay, from the lowest: compounds 2 and 3 (each within the scatter of the next); then compound 1.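

In this assay, methyl in place of hydrogen on a saturated chain carbon, two bonds along the chain from a double-bonded chain carbon, leaves the number within the scatter (a 1.1-fold higher number from compound 2 to compound 3 (0.06 log units; within the scatter)), so isopropyl and sec-butyl at this position cannot be told apart. The gap to the 1-methylprop-1-en-1-yl group of compound 1 remains beyond the scatter with this larger group (a 7.2-fold lower number from compound 1 to compound 3 (0.86 log units; beyond the scatter)), so compound 2 and compound 3 both stand clear of compound 1 by a similar margin.

The compounds shown leave open whether a longer chain, a ring such as cyclohexyl, or an amine or carboxylic acid at this position would keep the number where it is or move it. Nothing available explains the size of either step.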